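Propyl to Cyclohexyl on the Urea Nitrogen of Compound 2

The compounds below may be only part of what the source reports. "The series", "measured", "known", "first", "only" and "open" are said of these compounds alone.

Compound 2 `CCCNC(=O)/N=C(\N)Nc1cccc(-c2csc(N)n2)c1` is the weaker of the two compounds measured in a functional assay on membranes from Sf9 cells for agonist activity at histamine H2 receptor (Homo sapiens), read by scintillation counting and GTPgammaS binding, with a stated time of 90 min (a lower number here means a less potent compound, a higher number a more potent compound, by a factor of ten per unit of this negative logarithm), where compound 2 gives 4.91. Among the measured compounds shown here, its only neighbour is compound 1 `CCCCCCNC(=O)/N=C(\N)Nc1cccc(-c2csc(N)n2)c1`, which carries a hexyl group on the same amide-type nitrogen and gives 6.14 in this assay. For the measured compounds named here, the one measured step, a number 1.23 log units lower from compound 1 to compound 2 (beyond the scatter), shows that cutting the chain down to propyl costs a good deal of potency.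

Compound 3 `N/C(=N\C(=O)NC1CCCCC1)Nc1cccc(-c2csc(N)n2)c1` now replaces that propyl with a ring: cyclohexyl in place of propyl on an amide-type nitrogen. In carbon count this returns to the size of compound 1, though folded into a ring rather than stretched out as a chain. Going by the values given here, since the loss seen in the step from compound 1 to compound 2 was large and is the only guide, a gain of similar order is expected for compound 3, but not necessarily a full recovery, giving an estimated step of a number 0.79 log units higher from compound 2 to compound 3 (beyond the scatter). The expected value for compound 3 in this assay is therefore 5.7, with a range from 5 to 6.4.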

Compound 3, negative logarithm of the antagonist equilibrium constant: 5.4
For compound 3 the middle estimate is 0.30 log units above the measured one; measured number inside the range.
By their numbers in this assay, from the lowest: compound 2; then compound 3; then compound 1.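

In this assay, changing propyl to cyclohexyl on the amide-type nitrogen gives a number 0.49 log units higher from compound 2 to compound 3 (beyond the scatter) and so shows that this position can hold a ring as well as an open chain. The change from hexyl to cyclohexyl gives a number 0.74 log units lower from compound 1 to compound 3 (beyond the scatter) and places the ring between the two chains, with the hexyl chain of compound 1 the most potent of the three. No measurement here explains this order.

The compounds shown leave open whether a smaller ring such as cyclopentyl or a longer chain such as octyl would rise above compound 1 or fall below compound 3. They also leave open how a flat phenyl ring on the same nitrogen would compare with cyclohexyl.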